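From chloromethyl to azidomethyl in compound 4

The source may hold more compounds than are shown below. What is called first, only, known or untested is meant among the compounds shown, and "the series" means these compounds.

Measured so far in a functional assay on KB cells (Homo sapiens) for inhibition; on this read-out lower numbers stand for stronger inhibition and higher numbers for weaker inhibition:
compound 1 `CCOC[C@H]1O[C@@H](n2c(Cl)nc3cc(Cl)c(Cl)cc32)[C@H](OC(C)=O)[C@@H]1OC(C)=O` gives 60000 nM
compound 2 `CCCCOC[C@H]1O[C@@H](n2c(Cl)nc3cc(Cl)c(Cl)cc32)[C@H](OC(C)=O)[C@@H]1OC(C)=O` gives > 100000 nM as a limit of the assay
compound 3 `CC(=O)OC1C(CCl)OC(n2c(Cl)nc3cc(Cl)c(Cl)cc32)C1OC(C)=O` gives 90000 nM

Compound 3 at 90000 nM lies within the scatter of compound 1 at 60000 nM on these numbers. Compound 2 stands at the limit of > 100000 nM in this assay, at which 1 of the 3 values shown sits, and that value is only a limit. Compound 4 `CC(=O)OC1C(CN=[N+]=[N-])OC(n2c(Cl)nc3cc(Cl)c(Cl)cc32)C1OC(C)=O` carries azido in place of chloro on a saturated chain carbon bound to a saturated ring carbon, which is azido in place of chloro on a saturated chain carbon bound to a saturated ring carbon in full. Among the measured compounds shown here, the one measured step is a different change, and an at least 1.6-fold higher number from compound 1 to compound 2 (0.22 log units; that floor lies within the scatter) shows no step beyond the scatter, so in this assay no step beyond the scatter is expected here. The expected step is a 1.3-fold lower number from compound 3 to compound 4 (0.11 log units; within the scatter) on this estimate. The estimated value for compound 4 is 70000 nM with 25000 nM to 100000 nM as its expected range.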

Compound 4, half-maximal inhibitory concentration: 70000 nM
Beside the measured number, compound 4's estimate shows no gap at the digits printed; the measured number falls inside the stated range.
By their numbers in this assay, from the lowest: compounds 1, 4 and 3 (each within the scatter of the next). At a limit, above all of these: compound 2.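

In this assay, azido in place of chloro on a saturated chain carbon bound to a saturated ring carbon gives a 1.3-fold lower number from compound 3 to compound 4 (0.11 log units; within the scatter). At this place, a group of 3 heavy atoms thus replaces one of 1 heavy atom with no difference beyond the scatter, a reading that compound 1 and compound 2, which differ only in the ether chain, could not give. No measurement shown here accounts for this result. From the compounds shown here alone, whether an amine or a carboxylic acid at this place would move the number beyond the scatter remains open.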